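Shrinking the Ether Ring: From Oxolane to Oxetane

The source may hold more compounds than are shown below. What is called first, only, known or untested is meant among the compounds shown, and "the series" means these compounds.

Compound 3 `NC(=O)[C@@H](CCC(F)(F)F)N(C[C@@H]1CCCO1)S(=O)(=O)c1ccc(Cl)cc1` carries an oxolan-2-yl group on a saturated chain carbon bound to a sulfonamide nitrogen. In an in vitro ADME assay on microsomes from liver (Homo sapiens) for metabolic stability, read by HPLC (on this read-out higher numbers stand for fast clearance and lower numbers for slow clearance), compound 3 gives 210 mL/min/kg, the lowest of the two numbers reported, and its nearest neighbour is compound 1 `NC(=O)[C@@H](CCC(F)(F)F)N(CC1CCCC1)S(=O)(=O)c1ccc(Cl)cc1`, which in this assay gives 229 mL/min/kg. Compound 2 `NC(=O)[C@@H](CCC(F)(F)F)N(C[C@H]1CCCCO1)S(=O)(=O)c1ccc(Cl)cc1` reaches only a limit of this assay, > 300 mL/min/kg. The step of a 1.1-fold lower number from compound 1 to compound 3 (0.04 log units; within the scatter) stays within the scatter, and an at least 1.3-fold higher number from compound 1 to compound 2 (0.11 log units; that floor lies within the scatter) has a floor that also lies within it.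

Compound 4 `NC(=O)[C@@H](CCC(F)(F)F)N(C[C@H]1CCO1)S(=O)(=O)c1ccc(Cl)cc1` differs from compound 3 by oxetan-2-yl in place of oxolan-2-yl on a saturated chain carbon bound to a sulfonamide nitrogen. For the measured compounds named here, the only measured step in the same direction of ring change is an at least 1.4-fold lower number from compound 2 to compound 3 (0.15 log units; that floor lies within the scatter), whose floor lies within the scatter, so none of the measured steps points to a change beyond it. Compound 4 is therefore expected to show a 1.1-fold lower number from compound 3 to compound 4 (0.02 log units; within the scatter), a step no larger than the scatter. The estimate for compound 4 in this assay is 200 mL/min/kg, with a range from 110 mL/min/kg to 300 mL/min/kg.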

Compound 4, clearance: 63.8 mL/min/kg
Beside the measured number, compound 4's estimate is 3.1-fold (0.50 log units) above it; the measured number lies below the stated range.
By their numbers in this assay, from the lowest: compound 4; then compounds 3 and 1 (each within the scatter of the next). At a limit, above all of these: compound 2.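

In this assay, oxetan-2-yl in place of oxolan-2-yl gives a 3.3-fold lower number from compound 3 to compound 4 (0.52 log units; beyond the scatter), whereas no earlier step at this place, on a saturated chain carbon bound to a sulfonamide nitrogen, had shown a change beyond the scatter. The same group in place of cyclopentyl gives a 3.6-fold lower number from compound 1 to compound 4 (0.56 log units; beyond the scatter), setting compound 4 apart from compound 1 and compound 3, which lie within the scatter of each other. In place of oxan-2-yl it gives an at least 4.7-fold lower number from compound 2 to compound 4 (0.67 log units; beyond the scatter), which is only a floor, as compound 2 stands at a limit and not at a number: the limit of > 300 mL/min/kg in this assay, at which 1 of the 4 values shown sits.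

The compounds shown leave open whether this step belongs to the ring oxygen or to the four-membered ring, a question that a cyclobutyl group at this place would address. From the compounds shown here alone, the opposite configuration of the oxetan-2-yl group also remains open.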